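Swapping a methoxyphenyl for a dichlorophenyl on the chain

This account rests on a few compounds, and the source may have more. Where it says the series, first, only, none or still open, it means among the compounds named here.

Compound 1, `COc1cccc(CCC(=O)Nc2nc3ccccc3c(=O)s2)c1`: 225 nM
Compound 2, `O=C(CCCc1ccccc1)Nc1nc2ccc(Br)cc2c(=O)s1`: > 1000 nM

In an assay on CHO cells for displacement of a labelled ligand from adenosine receptor A2b (Homo sapiens), read by scintillation counting, with a stated time of 75 min (on this read-out lower numbers stand for stronger inhibition and higher numbers for weaker inhibition), compound 1 gives 225 nM. This is the only number shown; the other value is a limit. For compound 2 the read-out is the limit of > 1000 nM in this assay, at which 1 of the 2 values shown sits, so it is a limit of this assay and not a number. Among the compounds with values here, compound 1 therefore stands alone as the one measured value.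

Compound 3, `O=C(CCc1ccc(Cl)c(Cl)c1)Nc1nc2ccccc2c(=O)s1`, differs from compound 1 by 3,4-dichlorophenyl in place of 3-methoxyphenyl on a saturated chain carbon, two bonds along the chain from a carbonyl carbon. Within the data shown here, no step between two measured compounds covers a change of this kind, so no measured guide exists for its size or direction. In this assay the expected step is a 1.1-fold higher number from compound 1 to compound 3 (0.05 log units; within the scatter), a step that is not expected to go beyond the usual scatter of repeated measurements. For compound 3 the estimated inhibition constant is 250 nM, with a range from 80 nM to 900 nM.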

Compound 3, inhibition constant: > 1000 nM
Compound 3 ended at the assay's limit; the forecaster's own chance of this, stated with the estimate: 20%; middle value at least 4.0-fold (0.60 log units) from the limit.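

Within the data shown here, putting 3,4-dichlorophenyl in place of 3-methoxyphenyl on the chain gives an at least 4.4-fold higher number from compound 1 to compound 3 (0.64 log units; beyond the scatter) in this assay, and this is the first measured step at this position. It shows that, with the chain and the core held the same, the choice of ring substituents here is enough to weaken inhibition beyond the usual scatter. Compound 3 gives > 1000 nM, which is a limit and not a number, so the step gives only a minimum size: the limit of > 1000 nM in this assay, at which 2 of the 3 values shown sit.

The swap removes the methoxy group and adds two chlorines in a single change, so these compounds cannot tell which of the two matters. A 3-chlorophenyl or a 4-methoxyphenyl on the same chain would help to separate them, and a 3-hydroxyphenyl would test whether anything other than methoxy is tolerated at that ring position.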